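Swapping the five-membered ring on a salicylic acid core

The source may hold more compounds than are shown below. What is called first, only, known or untested is meant among the compounds shown, and "the series" means these compounds.

Measured so far:
- compound 1 `O=C(O)c1cc(-c2ccns2)ccc1O`: 80 mg/kg
- compound 2 `O=C(O)c1cc(-c2ccccn2)ccc1O`: 200 mg/kg

In a functional assay on the whole organism for inhibition, with Rattus norvegicus as the target, read by paw edema (on this read-out lower numbers stand for an effect already at smaller amounts and higher numbers for an effect only at larger amounts of compound), compound 1 gives the lower of the two numbers; compound 2 gives a higher one, a gap beyond the usual scatter. Compound 3 `O=C(O)c1cc(-c2ncc[nH]2)ccc1O` is not yet measured. It differs from compound 1 in one place: 1H-imidazol-2-yl in place of 1,2-thiazol-5-yl on an aromatic carbon. Within the data shown here, no measured pair shows this kind of change, so the step is expected to be small, and the number for compound 3 is estimated to rise only modestly from compound 1, with a 1.5-fold higher number from compound 1 to compound 3 (0.18 log units; within the scatter) in this assay. Compound 3 is expected to give 120 mg/kg, within 50 mg/kg to 300 mg/kg.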

Compound 3, dose for half-maximal effect: 200 mg/kg
For compound 3 the middle estimate is 1.7-fold (0.22 log units) below the measured one; low and high end bracket the measured number.
By their numbers in this assay, from the lowest: compound 1; then compounds 2 and 3 (each within the scatter of the next).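

In this assay, 1H-imidazol-2-yl in place of 1,2-thiazol-5-yl gives a 2.5-fold higher number from compound 1 to compound 3 (0.40 log units; beyond the scatter). This shows that the carbon para to the hydroxy group responds to which five-membered ring it carries, even though both rings have 5 heavy atoms and 2 hetero atoms. Nothing available explains this difference. Still open, going by these compounds, is how a group other than an aromatic ring, such as an amine or a longer chain, would fare at this position.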